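Dropping the chain hydroxy: compound 2 to compound 3

The source may hold more compounds than are shown below. What is called first, only, known or untested is meant among the compounds shown, and "the series" means these compounds.

Measured so far:
- compound 1 `CCCCCCCCCCCCCCCCc1c(C)c(N(C)C)nc(C)c1O` gives 85%
- compound 2 `Cc1c(N(C)C)nc(CCCCCCCCCCO)c(O)c1C` gives 74%

In a functional assay on cells (Lymphocyte, Homo sapiens), read by trypan blue exclusion, with a stated time of 16 h, tested at 2.5 uM (a higher number here means a stronger effect of the compound at the concentration tested, a lower number a weaker effect), compound 2 stands lowest of the two numbers, and the nearest value, that of compound 1, lies higher by a step beyond the scatter. Compound 3 `CCCCCCCCCCc1nc(N(C)C)c(C)c(C)c1O` is not yet measured. It differs from compound 2 by one counted change: hydrogen in place of hydroxy on a saturated chain carbon, ten or more bonds along the chain from an aromatic carbon. Going by the values given here, no step between measured compounds covers this change, so only the two values guide the expectation. For compound 3 the expected step is a number 8 percentage points higher from compound 2 to compound 3 (within the scatter), modest and upward, towards the value of compound 1 85%. The estimate for compound 3 is 82%, within 68% to 93%.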

Compound 3, a percentage reported as activity, at one concentration (the size of the read-out at that concentration, not a potency): 79%
Beside the measured number, compound 3's estimate is 3 percentage points above it; the measured number falls inside the stated range.
By their numbers in this assay, from the lowest: compounds 2, 3 and 1 (each within the scatter of the next, the first and the last beyond it).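

In this assay, hydrogen in place of hydroxy on a saturated chain carbon, ten or more bonds along the chain from an aromatic carbon, gives a number 5 percentage points higher from compound 2 to compound 3 (within the scatter). Going by these compounds alone, this is the first one-place comparison, and at the concentration tested the read-out does not separate the hydroxy-ended chain from the unsubstituted one. No measurement shown bears on why this is so. On these data alone, whether an amine or a carboxylic acid at that chain carbon would read the same remains open. The read-out also gives only the size of the effect at that single concentration.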